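A few compounds are considered here, and "the series" means these few. Any claim that something is new, unique, unknown or untested is made for them only; others in the source may bear on it.

Measured compounds:
- compound 1, `CN(Cc1ccc(N(C)C)cc1)Cc1cccc(CNc2ccnc3cc(Cl)ccc23)c1`: 9.67
- compound 2, `CN(Cc1ccc(N(C)C)cc1)Cc1ccccc1CNc1ccnc2cc(Cl)ccc12`: 9.71
- compound 3, `COc1ccc(CN(C)Cc2cccc(CNc3ccnc4cc(Cl)ccc34)c2)cc1`: 9.67

All three were run in a physicochemical assay for acid dissociation. Compound 1 and compound 3 differ in one place, (methoxy in place of dimethylamino on an aromatic carbon), and the step across that change is no change at the digits printed from compound 1 to compound 3 (within the scatter). Compound 2 has the same atoms as compound 1 joined differently; how the two cores differ is not broken down here. What the values show is that compound 2 and compound 1 lie within the scatter of each other in this assay, as do compound 2 and compound 3.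

Not yet measured is compound 4, `COc1ccc(CN(C)Cc2ccccc2CNc2ccnc3cc(Cl)ccc23)cc1`. It differs from compound 2 by methoxy in place of dimethylamino on an aromatic carbon. The place description is the same word for word as for the change from compound 1 to compound 3, so this is the same change on the other core. Among the compounds with values here, the only guide is the measured pair: the step from compound 1 to compound 3 was no change at the digits printed from compound 1 to compound 3 (within the scatter), and the expected step from compound 2 to compound 4 is therefore no change at the digits printed from compound 2 to compound 4 (within the scatter), resting on that single pair. On that basis compound 4 is expected to give about 9.71 in this assay, estimated to fall between 9.45 and 9.97.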

Compound 4, acid dissociation constant: 9.85
Compound 4: the middle estimate sits 0.14 log units below what was measured; low and high end bracket the measured number.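

In this assay, methoxy in place of dimethylamino gives a number 0.14 log units higher from compound 2 to compound 4 (within the scatter), and the same change on the core of compound 1 gives no change at the digits printed from compound 1 to compound 3 (within the scatter), so on both cores the step stays within the scatter and the change carries from one core to the other without a step that can be told from that scatter. This rests on two matched pairs and two cores only, so it does not show that the two steps truly differ, nor that the change would stay within the scatter on any further core in the series. Nothing shown here accounts for the values or says why the step stays this small on either core.

The compounds shown hold only dimethylamino and methoxy at this place, so the outcome in this assay with a carboxylic acid or a primary amine there remains open. Also open, from the compounds shown here alone, is whether a longer chain, such as ethoxy, would stay within the scatter on both cores.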